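The compounds below may be only part of what the source reports. "The series", "measured", "known", "first", "only" and "open" are said of these compounds alone.

Notes on the series

Compound 1 `C/C=C(\C)[C@H]1OC(=O)[C@@H](C)NC(=O)[C@H]([C@@H](C)CC)NC(=O)CN(C)C(=O)[C@@H](Cc2ccccc2)N(C)C(=O)[C@@H](C)NC(=O)[C@@H](CC(C)C)OC(=O)/C(C)=C/C[C@H](O)[C@@H]1C` and compound 3 `C/C=C(\C)[C@H]1OC(=O)[C@@H](C)NC(=O)[C@H]([C@@H](C)CC)NC(=O)CN(C)C(=O)[C@@H](Cc2ccc(Cl)cc2)N(C)C(=O)[C@H](C)NC(=O)[C@@H](CC(C)C)OC(=O)/C(C)=C/C[C@H](O)[C@@H]1C` share a core that differs between them; the difference between the two cores is not broken down here. In a functional assay on K562 cells (Homo sapiens) for cytotoxicity, read by CellTiter-Blue, with a stated time of 72 h (a lower number here means a stronger inhibitor, a higher number a weaker inhibitor), compound 1 gives 584 nM. Compound 2 `C/C=C(\C)[C@H]1OC(=O)[C@@H](C)NC(=O)[C@H]([C@@H](C)CC)NC(=O)CN(C)C(=O)[C@@H](Cc2ccccc2)N(C)C(=O)[C@@H](C)NC(=O)[C@@H](CC(C)C)OC(=O)/C(C)=C/C[C@H](OCSC)[C@@H]1C` carries (methylsulfanyl)methyl in place of hydrogen on an oxygen on a saturated carbon and gives 1190 nM in this assay, which is a 2.0-fold higher number from compound 1 to compound 2 (0.31 log units; beyond the scatter). Compound 3 gives 0.000011 nM in this assay, the lowest number of the three measured compounds, far apart from compound 1 and compound 2.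

Compound 4 `C/C=C(\C)[C@H]1OC(=O)[C@@H](C)NC(=O)[C@H]([C@@H](C)CC)NC(=O)CN(C)C(=O)[C@@H](Cc2ccc(Cl)cc2)N(C)C(=O)[C@H](C)NC(=O)[C@@H](CC(C)C)OC(=O)/C(C)=C/C[C@H](OCSC)[C@@H]1C` is not yet measured. It carries (methylsulfanyl)methyl in place of hydrogen on an oxygen on a saturated carbon, the same change as from compound 1 to compound 2, made at a place described in the same words. Going by the values given here, a step of similar size is expected, a 2.0-fold higher number from compound 3 to compound 4 (0.30 log units; within the scatter), because the only precedent for this change is a 2.0-fold higher number from compound 1 to compound 2 (0.31 log units; beyond the scatter). Compound 4 is therefore estimated at 0.000022 nM in this assay, within 0.000008 nM to 0.00006 nM.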

Compound 4, half-maximal inhibitory concentration: 7.1 nM
The estimate for compound 4 lay 320000-fold (5.51 log units) below the measured number; the whole stated range lies below it.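

On the core of compound 3, (methylsulfanyl)methyl in place of hydrogen on an oxygen on a saturated carbon gives a 650000-fold higher number from compound 3 to compound 4 (5.81 log units; beyond the scatter) in this assay. The change raises the number on both cores, but the size of the step does not carry from one core to the other: the same change on two cores in this assay, a 2.0-fold higher number (0.31 log units; beyond the scatter) from compound 1 to compound 2 and a 650000-fold higher number (5.81 log units; beyond the scatter) from compound 3 to compound 4, 320000-fold (5.50 log units) apart, beyond the scatter of two such steps With one pair per core, this does not show which part of the difference between the two cores goes with the larger step.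

From the compounds shown here alone, whether a methyl or an acetyl on the same oxygen shows a similar gap between the two cores remains open. So does the size of the step on a core carrying only part of that difference.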